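The source may hold more compounds than are shown below. What is called first, only, known or untested is meant among the compounds shown, and "the series" means these compounds.

Measured compounds:
- compound 1 `CC(=O)N[C@H]1[C@@H](OCCCCc2ccccc2)O[C@H](CO)[C@@H](O)[C@@H]1O`: > 50 uM
- compound 2 `C=CCCC(=O)N[C@H]1[C@@H](OCCc2ccccc2)O[C@H](CO)[C@@H](O)[C@@H]1O`: > 50 uM
- compound 3 `CCCCCCCCCCCCCCCCO[C@H]1O[C@H](COCC(CO)(CO)COS(=O)(=O)O)[C@@H](O)[C@H](O)[C@H]1NC(=O)CCCC`: 2.3 uM

In a functional assay on A-375 cells (Homo sapiens), read by thymidine incorporation (a lower number here means a stronger inhibitor, a higher number a weaker inhibitor), compound 1 gives > 50 uM, which is a limit of the assay and not a number. Compound 2 likewise gives > 50 uM in this assay, again only a limit. Among the measured compounds shown here, compound 3 is the one member of the series with a measured number, 2.3 uM in this assay; the other two values sit at the limit of > 50 uM in this assay, at which 2 of the 3 values shown sit, so no measured step between two compounds exists and compound 3 cannot be ranked against compounds 1 and 2 beyond the statement that its number lies inside the range the assay reports.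

Compound 4 `CCCCCCCCCCCCCCCCO[C@H]1O[C@H](COCC(O)CO)[C@@H](O)[C@H](O)[C@H]1NC(=O)CCCC` has not yet been measured. It differs from compound 3 in one place: 1,2-dihydroxyethyl in place of 2-hydroxy-1-(hydroxymethyl)-1-((sulfooxy)methyl)ethyl on a saturated chain carbon bound to an oxygen on a saturated carbon. For the measured compounds named here, with no measured step, the expectation for the step from compound 3 to compound 4 in this assay rests on the single number of compound 3 alone; the estimate is a moderate loss of potency, a 3.5-fold higher number from compound 3 to compound 4 (0.54 log units; beyond the scatter), likely beyond the scatter but not large. Compound 4 is therefore expected to give about 8 uM in this assay, within a range of 2 uM to 40 uM.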

Compound 4, concentration for 50% inhibition: 3 uM
Estimate against measurement, compound 4: 2.7-fold (0.43 log units) above; the measured number falls inside the stated range.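

In this assay, among the compounds shown here, the first readable step is a 1.3-fold higher number from compound 3 to compound 4 (0.12 log units; within the scatter), so on a saturated chain carbon bound to an oxygen on a saturated carbon, 2-hydroxy-1-(hydroxymethyl)-1-((sulfooxy)methyl)ethyl and the much smaller 1,2-dihydroxyethyl cannot be told apart. The sulfooxy group is therefore not needed for a measured number in this pair, since compound 4 lacks it and gives 3 uM in the same assay. No measurement shown explains why the two groups read alike.

Still open, as far as these compounds go, is whether this position needs a hydroxyl-bearing group at all, which an amine, a carboxylic acid or a plain methyl ether in the same place would test. From the compounds shown here alone, the hexadecyl chain and the butanoyl amide are common to compounds 3 and 4, and steps to compounds 1 and 2 cannot be read, so the part played by a shorter or longer chain at either site remains unknown.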